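Trifluoromethyl in Place of Hydrogen: an Expected Weakening

The compounds below may be only part of what the source reports. "The series", "measured", "known", "first", "only" and "open" are said of these compounds alone.

Compound 1, `COc1ccc(CN(C(=O)CSc2nc3ccccc3s2)c2cc(OC)c(OC)c(OC)c2)cc1`: 426 nM in a functional assay on HCT-116 cells (Homo sapiens) for antiproliferative activity, read by MTT assay, with a stated time of 48 h; a lower number here means a stronger inhibitor, a higher number a weaker inhibitor
Compound 2, `COc1ccc(CN(C(=O)CSc2nc3ccccc3s2)c2cc(OC)c(OC)c(OC)c2)cc1F`: 1830 nM in this assay
Compound 3, `COc1cc(N(Cc2ccc(F)cc2)C(=O)CSc2nc3ccccc3s2)cc(OC)c1OC`: 59800 nM in this assay

Compound 1 gives the lowest number of the three measured compounds: a 4.3-fold higher number from compound 1 to compound 2 (0.63 log units; beyond the scatter), and a 140-fold higher number from compound 1 to compound 3 (2.15 log units; beyond the scatter). Between the other two, a 33-fold higher number from compound 2 to compound 3 (1.51 log units; beyond the scatter).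

Compound 4, `COc1ccc(CN(C(=O)CSc2nc3ccccc3s2)c2cc(OC)c(OC)c(OC)c2)cc1C(F)(F)F`, differs from compound 1 by trifluoromethyl in place of hydrogen on an aromatic carbon. The step that bears on this is the one at the same aromatic carbon, where a 4.3-fold higher number from compound 1 to compound 2 (0.63 log units; beyond the scatter), a modest step beyond the scatter. Putting a larger group, trifluoromethyl, at that carbon is expected to weaken the inhibitor by a similar or somewhat greater amount, a 5.9-fold higher number from compound 1 to compound 4 (0.77 log units; beyond the scatter). Compound 4 is therefore estimated at 2500 nM in this assay, within a range from 600 nM to 10000 nM.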

Compound 4, half-maximal inhibitory concentration: > 80000 nM
Compound 4: only a limit was reported (the forecaster's own chance of this, stated with the estimate: 2%); middle value at least 32-fold (1.50 log units) from the limit.
By their numbers in this assay, from the lowest: compound 1; then compound 2; then compound 3. At a limit, above all of these: compound 4.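

The value for compound 4, > 80000 nM, is a limit of this assay, not a number. Even so, this aromatic carbon, ortho to a methoxy group, proves highly sensitive to its substituent: trifluoromethyl in place of hydrogen gives an at least 180-fold higher number from compound 1 to compound 4 (2.27 log units; beyond the scatter), and trifluoromethyl in place of fluoro gives an at least 43-fold higher number from compound 2 to compound 4 (1.64 log units; beyond the scatter), whereas fluoro in place of hydrogen gives a 4.3-fold higher number from compound 1 to compound 2 (0.63 log units; beyond the scatter), so the modest cost of fluoro does not carry over to trifluoromethyl. The remaining step, an at least 1.3-fold higher number from compound 3 to compound 4 (0.12 log units; that floor lies within the scatter), cannot be read: its floor lies within the scatter.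

On these data alone, whether a methyl group, a chlorine or an amine at this carbon would stay closer to compound 1 remains open. So does the true value of compound 4.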